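The compounds below may be only part of what the source reports. "The series", "measured", "known", "first", "only" and "open" are said of these compounds alone.

Compound 1: `COc1ccc2c(=O)c(/C=C/C(=O)Nc3cc(C)ccc3C)coc2c1` — in a functional assay on L02 cells (Homo sapiens) for inhibition, read by MTT assay, with a stated time of 48 h (a lower number here means a stronger inhibitor, a higher number a weaker inhibitor), compound 1 gives only a limit, > 200000 nM.
Compound 2: `COc1ccc2c(=O)c(/C=C/C(=O)NCc3ccccc3F)coc2c1` — in this assay compound 2 likewise gives only a limit, > 200000 nM.

Among the compounds with values here, compound 2 thus stands at the limit of this assay, as does compound 1; the single measured step, a step that the two limits leave unreadable from compound 1 to compound 2, cannot be sized because of the limit of > 200000 nM in this assay, at which 2 of the 2 values shown sit. Compound 3, `COc1ccc2c(=O)c(/C=C/C(=O)NCc3ccc(F)cc3F)coc2c1`, differs from compound 2 by fluoro in place of hydrogen on an aromatic carbon. Within the data shown here, no measured step shows what this change does here, so no shift beyond the scatter is expected, and compound 3 will most likely also sit at the limit. The estimated step that the limit leaves unreadable from compound 2 to compound 3 is essentially flat. For compound 3 the expected value is 250000 nM, within 100000 nM to 600000 nM.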

Compound 3, half-maximal inhibitory concentration: > 200000 nM
Compound 3 gave a limit, no number; the forecaster's own chance of this, stated with the estimate: 85%; the middle value lies beyond the limit too.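

Compound 3 also gives only a limit, so no step among compound 1, compound 2 and compound 3 can be read, because all stand at one limit: the limit of > 200000 nM in this assay, at which 3 of the 3 values shown sit.

How strongly any of these compounds inhibits remains open, as does whether the added fluoro changes anything.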